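Compound 1 and the chloro exchange: notes on the series

The compounds below may be only part of what the source reports. "The series", "measured", "known", "first", "only" and "open" are said of these compounds alone.

Values in a functional assay on A-375 cells (Homo sapiens) for cytotoxicity, read by CCK-8 assay, with a stated time of 24 h; on this read-out higher numbers stand for weaker inhibition and lower numbers for stronger inhibition:
- compound 1 `COc1ccccc1Oc1c(N)nc(-c2ccc(C)cc2)nc1Cl`: > 80000 nM
- compound 2 `COc1ccc(-c2nc(N)c(Oc3ccccc3OC)c(Cl)n2)cc1`: > 80000 nM
- compound 3 `COc1ccccc1Oc1c(N)nc(-c2ccc(I)cc2)nc1Cl`: 480 nM

Compound 1 gives > 80000 nM in this assay. This is a limit of the assay and not a number. Compound 2 gives > 80000 nM, which is likewise a limit. Among the compounds with values here, compound 1 therefore stands at the limit of > 80000 nM in this assay, at which 2 of the 3 values shown sit, and compound 3 is the only one with a number, at 480 nM.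

Compound 4 `COc1ccccc1Oc1c(N)nc(-c2ccc(C)cc2)nc1OCCO` has not been measured yet. It carries 2-hydroxyethoxy in place of chloro on an aromatic carbon.

Within the data shown here, no measured step touches the chloro. All three change the group that is methyl in compound 1, so they bear on this exchange only indirectly. There is a step that the two limits leave unreadable from compound 1 to compound 2. The large shifts, an at least 160-fold lower number from compound 1 to compound 3 (2.22 log units; beyond the scatter) and an at least 160-fold lower number from compound 2 to compound 3 (2.22 log units; beyond the scatter), both come with iodo, and compound 4 keeps the methyl of compound 1. Among the measured compounds shown here, no large step towards lower numbers is therefore expected in this assay, and the most likely outcome is a reading at or near the same limit.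

The expected step is a number no higher from compound 1 to compound 4 (the limit leaves the size open).

Compound 4 is estimated at 80000 nM, with an expected range of 20000 nM to 160000 nM.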

Compound 4, half-maximal inhibitory concentration: 2380 nM
Beside the measured number, compound 4's estimate is 34-fold (1.53 log units) above it; measured number below the stated range.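

In this assay, within the data shown here, the chloro position, on an aromatic carbon next to the ring nitrogen, now proves able to move the read-out, which no earlier step could show, since all of them changed the group that is methyl in compound 1: 2-hydroxyethoxy in place of chloro gives an at least 33-fold lower number from compound 1 to compound 4 (1.52 log units; beyond the scatter). Iodo is thus no longer the only single change from compound 1 that leads to a number, and the methyl of compound 1 does not by itself hold a compound at the limit. Compound 1 gives > 80000 nM, which is a limit and not a number, so this step has a lower bound but no exact size, and the series still sits largely at that limit: the limit of > 80000 nM in this assay, at which 2 of the 4 values shown sit.

The compounds shown leave open which part of the 2-hydroxyethoxy group goes with the shift, and a methoxy, a 3-hydroxypropoxy chain or a 2-aminoethoxy chain at the same position would separate the ether oxygen, the chain length and the terminal hydroxyl. Also open, going by these compounds, is whether this exchange and the iodo of compound 3 would add up when combined in one compound.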